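Opening a fused diamine into an open chain

The compounds below may be only part of what the source reports. "The series", "measured", "known", "first", "only" and "open" are said of these compounds alone.

Of the compounds shown here, two have so far been measured in an assay on isolated protein for inhibition of DNA topoisomerase 1 (Homo sapiens), with a stated time of 15 min; on this read-out higher numbers stand for weaker inhibition and lower numbers for stronger inhibition. Compound 1 `O=C(O)c1cn(Cc2ccc(-c3ccccc3)cc2)c2cc(N3CC4CNCC4C3)c(F)cc2c1=O` gives 33300 nM in this assay. Compound 2 `COc1c(N2CC[C@@H](CN)C2)c(F)cc2c(=O)c(C(N)=O)cn(Cc3ccc(-c4ccccc4)cc3)c12`, which differs in several parts of its structure, gives 184000 nM in this assay. Compound 1 thus holds the lower of the two numbers, and the gap to compound 2 lies beyond the usual scatter of repeated measurements.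

Compound 3 `CNCCCNc1cc2c(cc1F)c(=O)c(C(=O)O)cn2Cc1ccc(-c2ccccc2)cc1` has not been measured yet. It is reached from compound 1 by a single change: a group of 6 heavy atoms (4 carbon, 2 nitrogen; no ring) in place of a group of 8 heavy atoms (6 carbon, 2 nitrogen; 2 five-membered non-aromatic rings with 1 hetero atom each), on an aromatic carbon. The two fused five-membered rings are thus replaced by an open chain carrying the same count of nitrogen atoms, at the same position on the shared core.

For the measured compounds named here, no pair of measured compounds shows what such an exchange does here, so the size of the step can only be guessed. Compound 3 is expected to land close to compound 1, with a mild shift toward weaker inhibition, a step of a 1.5-fold higher number from compound 1 to compound 3 (0.18 log units; within the scatter) in this assay. The value of compound 3 in this assay is estimated at 50000 nM, within a range from 15000 nM to 170000 nM.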

Compound 3, half-maximal inhibitory concentration: 63600 nM
For compound 3 the middle estimate is 1.3-fold (0.10 log units) below the measured one, and the stated range covers the measured number.
By their numbers in this assay, from the lowest: compounds 1 and 3 (each within the scatter of the next); then compound 2.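

In this assay, replacing the two fused five-membered rings with the open (3-(methylamino)propyl)amino group gives a 1.9-fold higher number from compound 1 to compound 3 (0.28 log units; within the scatter) and so no change that can be told apart from the scatter. At this position, on an aromatic carbon ortho to a fluoro group, the fused ring system can therefore be opened into a chain with no ring and the same count of nitrogen atoms without a clear loss of inhibition. Compounds 1 and 2 could not show this, as they differ in several parts of their structure, and no measurement here explains why the exchange makes so little difference.

This single step leaves open how far the position tolerates other groups, for instance a longer chain, a chain ending in a dimethylamino group, or a single six-membered piperazine ring. A chain with no nitrogen at its far end, such as a simple propylamino group, would test whether that second nitrogen matters at all, which neither compound 1 nor compound 3 can tell.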